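From amino to isopropoxy: how large a step?

A few compounds are considered here, and "the series" means these few. Any claim that something is new, unique, unknown or untested is made for them only; others in the source may bear on it.

In a functional assay on MCF7 cells (Homo sapiens) for inhibition, with a stated time of 48 h (a lower number here means a stronger inhibitor, a higher number a weaker inhibitor), compound 1 `COc1cc(Sc2c[nH]c3ccc(Cl)cc23)cc(OC)c1OC` with chloro gives 77 nM and compound 2 `COc1cc(Sc2c[nH]c3ccc(I)cc23)cc(OC)c1OC` with iodo gives 68 nM on the same core. Exchanging those two groups means a 1.1-fold lower number from compound 1 to compound 2 (0.05 log units; within the scatter) so the pair cannot be told apart. Compound 3 `COc1cc(Sc2c[nH]c3ccc(N)cc23)cc(OC)c1OC` carries amino at that place and gives 260 nM as the highest of the three numbers, which makes it the weakest inhibitor so far.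

Compound 4 `COc1cc(Sc2c[nH]c3ccc(OC(C)C)cc23)cc(OC)c1OC` has not been measured. Among the measured compounds shown here, it carries isopropoxy in place of amino on an aromatic carbon and no measured compound holds that group. The closest guides are a 3.4-fold higher number from compound 1 to compound 3 (0.53 log units; beyond the scatter) and a 3.8-fold higher number from compound 2 to compound 3 (0.58 log units; beyond the scatter) and both are modest. They show only that amino gives a higher number than chloro and iodo, so replacing amino may lower the number, yet nothing measured shows where isopropoxy falls. A step no larger than those two, leaning toward a lower number in this assay is therefore expected, and a 1.7-fold lower number from compound 3 to compound 4 (0.24 log units; within the scatter) is the estimated step. The estimate for compound 4 is 150 nM with 60 nM to 400 nM as its expected span.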

Compound 4, half-maximal inhibitory concentration: 1500 nM
Compound 4: the middle estimate sits 10-fold (1.00 log units) below what was measured; the measured number lies above the stated range.
By their numbers in this assay, from the lowest: compounds 2 and 1 (each within the scatter of the next); then compound 3; then compound 4.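

In this assay this place on the shared core turns out to be far less tolerant than chloro, iodo and amino suggested, and isopropoxy makes compound 4 the weakest inhibitor of the four. Replacing amino with isopropoxy gives a 5.8-fold higher number from compound 3 to compound 4 (0.76 log units; beyond the scatter) and stays in the modest range, but the steps from the two halogen compounds are large, with a 19-fold higher number from compound 1 to compound 4 (1.29 log units; beyond the scatter) and a 22-fold higher number from compound 2 to compound 4 (1.34 log units; beyond the scatter) on the same core. So a change here can do much more than the earlier compounds showed, and nothing available explains why the number rises so far.

The step from amino to isopropoxy exchanges 1 heavy atom for 4 heavy atoms and also goes from 1 hydrogen-bond donor to 0 hydrogen-bond donors, and these four values cannot separate the two differences. Groups such as hydroxyl, ethoxy or dimethylamino at this place could help to show whether the higher number follows the larger group, the missing donor or something else, and how steeply the number climbs between amino and isopropoxy remains open.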